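The source may report more compounds than this note shows. Statements on the series, on what has been measured and on what is new or still open speak of the compounds shown alone.

Measured so far:

- Compound 1, `OCCCNc1nc(-c2ccccc2)nc2c1nnn2Cc1ccccc1` — in an assay on isolated protein for binding affinity to adenosine receptor A1 (Bos taurus) (on this read-out higher numbers stand for weaker inhibition and lower numbers for stronger inhibition), compound 1 gives 21400000 nM
- Compound 2, `OCCCNc1nc(-c2ccccc2)nc2c1nnn2Cc1ccccc1F` — compound 2 gives 3700000 nM
- Compound 3, `CCCCNc1nc(-c2ccccc2)nc2c1nnn2Cc1ccccc1` — compound 3 gives 11000000 nM

Among these three, compound 2 stands lowest on this assay, with compound 3 nearest and compound 1 furthest, both beyond the scatter. The move from compound 1 to compound 2, fluoro in place of hydrogen on an aromatic carbon, gave a 5.8-fold lower number from compound 1 to compound 2 (0.76 log units; beyond the scatter). The move from compound 1 to compound 3, methyl in place of hydroxy on a saturated chain carbon, gave a 1.9-fold lower number from compound 1 to compound 3 (0.29 log units; within the scatter).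

Compound 4, `CC(O)CNc1nc(-c2ccccc2)nc2c1nnn2Cc1ccccc1F`, is not yet measured. It differs from compound 2 by 1-hydroxyethyl in place of 2-hydroxyethyl on a saturated chain carbon bound to a nitrogen on an aromatic ring. Among the measured compounds shown here, no measured step shifts the hydroxy along the chain in this way; the only step touching that chain carbon is a 1.9-fold lower number from compound 1 to compound 3 (0.29 log units; within the scatter), which stayed within the scatter when the hydroxy was removed altogether. On that basis the expected step from compound 2 to compound 4 is none beyond the scatter, written as no change at the digits printed from compound 2 to compound 4 (within the scatter). Compound 4 is therefore estimated at 3700000 nM, with a range from 1200000 nM to 12000000 nM.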

Compound 4, inhibition constant: 4800000 nM
Beside the measured number, compound 4's estimate is 1.3-fold (0.11 log units) below it, within the range that was stated.
By their numbers in this assay, from the lowest: compounds 2 and 4 (each within the scatter of the next); then compounds 3 and 1 (each within the scatter of the next).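

In this assay, moving the hydroxy from 3-hydroxypropyl to 2-hydroxypropyl on the chain, with the fluoro kept, gave a 1.3-fold higher number from compound 2 to compound 4 (0.11 log units; within the scatter) and so left compound 4 indistinguishable from compound 2. The earlier compounds had shown only that replacing the hydroxy with methyl gave a 1.9-fold lower number from compound 1 to compound 3 (0.29 log units; within the scatter) on the compound without fluoro; this result adds that shifting the hydroxy along the chain also stays within the scatter on the fluoro compound, whereas the fluoro step itself gave a 5.8-fold lower number from compound 1 to compound 2 (0.76 log units; beyond the scatter) and remains the only change here beyond it. No evidence is available that accounts for this result.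

From the compounds shown here alone, whether an amine or a carboxylic acid in place of the hydroxy, or a longer chain, would move the number beyond the scatter remains open. Also open, going by these compounds, is whether 2-hydroxypropyl would behave the same way on the compound without fluoro.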